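This account rests on a few compounds, and the source may have more. Where it says the series, first, only, none or still open, it means among the compounds named here.

Working notes on the series. Of the compounds shown here, two have numbers so far in a physicochemical assay for lipophilicity, measured as octanol-water partition, at pH 7.4; a higher number here means a more lipophilic compound, a lower number a more polar compound. Compound 1 (`CN(C(=O)c1cc(-c2ccccc2Cl)on1)[C@H]1CN(S(=O)(=O)c2ccccc2)C[C@@H]1C(=O)N[C@H]1CCCNC1`) gives 1.6. Compound 2 (`CN(C(=O)[C@H]1CN(S(=O)(=O)c2ccccc2)C[C@@H]1NC(=O)c1cc(-c2ccccc2Cl)on1)[C@H]1CCCNC1`) gives 1.7, which lies within the scatter of compound 1, so no order is read into this pair. Within the data shown here, the two measured compounds do not differ in one place only, and they offer no measured step for the change considered here.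

Compound 3 (`CN(C(=O)[C@H]1CN(S(=O)(=O)c2ccccc2)C[C@@H]1N(C)C(=O)c1cc(-c2ccccc2Cl)on1)[C@H]1CCCNC1`) has not yet been measured. It follows from compound 2 by methyl in place of hydrogen on an amide-type nitrogen. Among the measured compounds shown here, with no measured pair carrying this change, the only anchor is compound 2 at 1.7, and the range has to stay fairly wide. In this assay a small upward step is expected, one not clearly beyond the scatter. The estimated step is a number 0.20 log units higher from compound 2 to compound 3 (within the scatter). Compound 3 is expected at 1.9, with an estimated range from 1.5 to 2.3.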

Compound 3, distribution coefficient: 1.6
The estimate for compound 3 lay 0.30 log units above the measured number; low and high end bracket the measured number.
By their numbers in this assay, from the lowest: compounds 1, 3 and 2 (each within the scatter of the next).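

In this assay, the series now has its first readings of methyl in place of hydrogen on an amide-type nitrogen: a number 0.10 log units lower from compound 2 to compound 3 (within the scatter) at the nitrogen changed in that pair, and no change at the digits printed from compound 1 to compound 3 (within the scatter) at the second amide-type nitrogen of the shared core. Both steps are within the scatter, so at neither nitrogen does this assay resolve an order between the compound carrying the hydrogen and compound 3, and the two nitrogens cannot be told apart by this replacement. The pair of steps ends at one compound and gives no explanation for this outcome, and no independent measurement bears on it.

Still open is whether an ethyl group or a longer chain on either amide-type nitrogen would stay within the scatter of compound 3, since methyl is the only group shown entering at these places. Also open, on these data alone, is whether a hydroxyethyl chain, or an amine or carboxylic acid carried on such a chain, would give a step that this assay can resolve at either nitrogen.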